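Lactam nitrogen aryl substituents in a metabotropic glutamate receptor 5 series

The source may hold more compounds than are shown below. What is called first, only, known or untested is meant among the compounds shown, and "the series" means these compounds.

Measured compounds:
Compound 1, `O=C1CC(c2nc(-c3cccc(Cl)c3)no2)CN1c1ccccc1Cl`, gives 680 nM in an in vitro functional assay on HEK293-A cells for negative allosteric modulation of metabotropic glutamate receptor 5 (Homo sapiens), read by FLIPR and calcium flux; on this read-out higher numbers stand for weaker inhibition and lower numbers for stronger inhibition.
Compound 2, `Cc1cccc(N2CC(c3nc(-c4cccc(Cl)c4)no3)CC2=O)c1`, gives 2300 nM in this assay.
Compound 3, `Cc1ccc(N2CC(c3nc(-c4cccc(Cl)c4)no3)CC2=O)cc1`, gives > 10000 nM in this assay.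

The value of compound 3 is a limit of the assay and not a number, so compound 3 sits at the limit of > 10000 nM in this assay, at which 1 of the 3 values shown sits, the weakest position among the three. Compound 4, `COc1cccc(N2CC(c3nc(-c4cccc(Cl)c4)no3)CC2=O)c1`, differs from compound 3 in that (3-methoxyphenyl in place of 4-methylphenyl on an amide-type nitrogen in a ring). Of the measured steps, an at least 4.3-fold higher number from compound 2 to compound 3 (0.63 log units; beyond the scatter) bears most directly on this change, since it moved a substituent from the same 3-position of the phenyl ring to the 4-position and weakened inhibition; a 3.4-fold higher number from compound 1 to compound 2 (0.53 log units; beyond the scatter) and an at least 14-fold higher number from compound 1 to compound 3 (1.16 log units; beyond the scatter) show that the 2-chlorophenyl of compound 1 is the strongest of the three aryl groups. Reversing the 2>3 direction, a lower number is expected for compound 4 in this assay. Compound 4 is estimated at 3000 nM, within 1000 nM to 10000 nM. The expected step is an at least 3.3-fold lower number from compound 3 to compound 4 (0.52 log units; beyond the scatter).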

Compound 4, half-maximal inhibitory concentration: 690 nM
The estimate for compound 4 lay 4.3-fold (0.64 log units) above the measured number; measured number outside the range, below it.
By their numbers in this assay, from the lowest: compounds 1 and 4 (each within the scatter of the next); then compound 2. At a limit, above all of these: compound 3.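

Compound 3 is held at a limit of the assay and not a number: the limit of > 10000 nM in this assay, at which 1 of the 4 values shown sits.

In this assay, an at least 14-fold lower number from compound 3 to compound 4 (1.16 log units; beyond the scatter), so this step gives only a bound, while a 3.3-fold lower number from compound 2 to compound 4 (0.52 log units; beyond the scatter) shows that, with the group kept on the same ring position, methoxy in place of methyl alone moves the number beyond the scatter. Further, a 1.0-fold higher number from compound 1 to compound 4 (0.01 log units; within the scatter), so 3-methoxyphenyl and 2-chlorophenyl cannot be told apart on this nitrogen, and the earlier drop from compound 1 to compound 2 does not hold for every group at the 3-position.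

The compounds shown leave open whether 2-methoxyphenyl or 4-methoxyphenyl would match 3-methoxyphenyl, so the effects of group and ring position remain unseparated for methoxy. Also open, as far as these compounds go, is whether hydroxy, ethoxy or dimethylamino at the 3-position would match methoxy.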